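This account rests on a few compounds, and the source may have more. Where it says the series, first, only, none or still open, it means among the compounds named here.

Working notes on the spiro-amide series.

Compound 1 `CC(C)(C)c1ccc(C(=O)N2CCC3(CC2)C(=O)N(CC(=O)NCCN)CN3c2ccccc2)cc1` gives 7000 nM in an assay on HEK293 cells for displacement of a labelled ligand from NPC1-like intracellular cholesterol transporter 1 (Homo sapiens); a higher number here means a weaker inhibitor, a lower number a stronger inhibitor. Among the measured compounds shown here, compound 2 `CCOC(=O)C1CCN(C(=O)CN2CN(c3ccccc3)C3(CCN(C(=O)c4ccc(C(C)(C)C)cc4)CC3)C2=O)CC1` gives 3100 nM; the only measured step is a 2.3-fold lower number from compound 1 to compound 2 (0.35 log units; beyond the scatter), a replacement of the (2-aminoethyl)amino group at the terminal amide carbonyl. Compound 3 `COC(=O)CCNC(=O)CN1CN(c2ccccc2)C2(CCN(C(=O)c3ccc(C(C)(C)C)cc3)CC2)C1=O` gives "not determined" (no result reported) in this assay, so it stands nowhere on the scale and cannot anchor a step.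

Compound 4 `CC(C)(C)c1ccc(C(=O)N2CCC3(CC2)C(=O)N(CC(=O)NCCCCN)CN3c2ccccc2)cc1` is the next compound. Relative to compound 3 it carries 2-aminoethyl in place of methoxycarbonyl on a saturated chain carbon, two bonds along the chain from an amide-type nitrogen. Read through the side chain, compound 4 is the (4-aminobutyl)amino analogue of compound 1, which carries (2-aminoethyl)amino at the same carbonyl. The measured step of a 2.3-fold lower number from compound 1 to compound 2 (0.35 log units; beyond the scatter) concerns a different replacement at that carbonyl and bears on the present change only as a sign that alterations there move this assay modestly. No step beyond the scatter is expected in this assay for the added chain length. The expectation rests on compound 1, which gives 7000 nM. Compound 4 is therefore expected to give about 7000 nM, estimated within 2500 nM to 20000 nM.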

Compound 4, half-maximal inhibitory concentration: 14500 nM
Estimate against measurement, compound 4: 2.1-fold (0.32 log units) below; the range from low to high includes it.
By their numbers in this assay, from the lowest: compound 2; then compound 1; then compound 4.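

In this assay, the step of a 2.1-fold higher number from compound 1 to compound 4 (0.32 log units; beyond the scatter) shows that this position responds to the length of the amine-bearing chain: (4-aminobutyl)amino reads weaker than (2-aminoethyl)amino, although only these two chain lengths are available. The step of a 4.7-fold higher number from compound 2 to compound 4 (0.67 log units; beyond the scatter) leaves compound 2 as the strongest of the three measured inhibitors and compound 4 as the weakest, so neither amine-bearing chain matches 4-(ethoxycarbonyl)piperidin-1-yl at this carbonyl carbon. No measurement offered here accounts for either step.

As far as these compounds go, two points do not establish a trend, so it remains open how (3-aminopropyl)amino or a longer aminoalkyl chain would read. The step from compound 2 also changes the ring and the ester together, leaving open whether a piperidine without the ester, or one bearing a carboxylic acid, would hold the lower number.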